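Notes on the ring exchange within the shared core series

A few compounds are considered here, and "the series" means these few. Any claim that something is new, unique, unknown or untested is made for them only; others in the source may bear on it.

Measured compounds:
compound 1, `Cc1cc(C#N)cc(C)c1Oc1nc(Nc2ccc(C#N)cc2)ncc1-c1ccco1`, > 306000 nM in an ADME assay on MT4 cells (Homo sapiens) for cytotoxicity, read by MTT assay, with a stated time of 5 days; on this read-out higher numbers stand for lower toxicity in this test and lower numbers for higher toxicity in this test
compound 2, `Cc1cc(C#N)cc(C)c1Oc1nc(Nc2ccc(C#N)cc2)ncc1-c1ccsc1`, 3920 nM

Compound 1 reaches only (the limit of > 306000 nM in this assay, at which 1 of the 2 values shown sits), a limit rather than a number. Among the measured compounds shown here, compound 2 is therefore the only compound with a number in this assay, so no ranking among the measured compounds is possible. For the measured compounds named here, the one measured step, an at least 78-fold lower number from compound 1 to compound 2 (1.89 log units; beyond the scatter), shows that exchanging the five-membered ring at this position moves the number strongly.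

Compound 3, `Cc1cc(C#N)cc(C)c1Oc1nc(Nc2ccc(C#N)cc2)ncc1-c1cccc2ccccc12`, is not yet measured. Its change from compound 2 is naphthalen-1-yl in place of thiophen-3-yl on an aromatic carbon. Going by the values given here, the single step available concerns a different exchange at the same place and gives no direction for a carbon-only two-ring system entering here. For compound 3 in this assay the expected step is a 1.3-fold lower number from compound 2 to compound 3 (0.12 log units; within the scatter), which is within the scatter. The estimate for compound 3 is 3000 nM, with a range from 600 nM to 15000 nM.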

Compound 3, half-maximal cytotoxic concentration: > 267000 nM
Compound 3: a limit, no number; the forecaster's own chance of this, stated with the estimate: 10%; middle value at least 89-fold (1.94 log units) away from the limit.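

In this assay, naphthalen-1-yl in place of thiophen-3-yl on this aromatic carbon, para to the (4-cyanophenyl)amino group, gives an at least 68-fold higher number from compound 2 to compound 3 (1.83 log units; beyond the scatter), so the number at this position also moves strongly with a two-ring carbon-only group and not only with an exchange of five-membered rings. Compound 3 gives a limit, not a number: the limit of > 267000 nM in this assay, at which 1 of the 3 values shown sits. The limits of compound 1 and compound 3 leave the step between them unreadable, but furan-2-yl and naphthalen-1-yl now both end at limits, and of the three groups only thiophen-3-yl gives a number.

As far as these compounds go, whether thiophen-2-yl or phenyl at this place would give a number like that of compound 2 stays open. So does the outcome for a non-aromatic group such as an amine or a carboxylic acid.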